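A few compounds are considered here, and "the series" means these few. Any claim that something is new, unique, unknown or untested is made for them only; others in the source may bear on it.

Measured compounds and their values in a functional assay on MCF7 cells (Homo sapiens) for cytotoxicity, read by MTT assay; on this read-out lower numbers stand for stronger inhibition and higher numbers for weaker inhibition:
compound 1, `CC(C)[C@H](NC(=S)Nc1cc(C(F)(F)F)cc(C(F)(F)F)c1)c1nc2ccccc2[nH]1`, 24300 nM;
compound 2, `C[C@H](NC(=S)Nc1cc(C(F)(F)F)cc(C(F)(F)F)c1)c1nc2ccccc2[nH]1`, 187000 nM;
compound 3, `C[C@H](NC(=S)NCc1ccccc1)c1nc2ccccc2[nH]1`, 217000 nM.

Compound 2 stands second highest of the three numbers. Its nearest neighbour is compound 3, whose value 217000 nM lies within the scatter of it, so no order between these two can be read. Compound 1 is furthest away, and the step of a 7.7-fold higher number from compound 1 to compound 2 (0.89 log units; beyond the scatter) is the only one measured that crosses more than the scatter; it concerns the methyl in place of isopropyl on the saturated chain carbon bound to the amide-type nitrogen and the aromatic carbon.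

Compound 4, `C[C@@H](NC(=S)Nc1cc(C(F)(F)F)cc(C(F)(F)F)c1)c1nc2ccccc2[nH]1`, is not yet measured. Its difference from compound 2 is this: the two compounds have the same atoms and bonds and differ only in configuration as drawn: 1 of 1 stereo elements differ; a stereocentre at a saturated chain carbon is drawn S in compound 2 and R in compound 4. For the measured compounds named here, no measured step among the three compounds touches configuration at this stereocentre, so none of them bears on the change. The only thing to go on is the value of compound 2 itself, 187000 nM. The expectation is therefore a step of no set direction, and most likely none beyond the scatter, though the range must stay wide since enantiomers are unprobed here.

Compound 4 is estimated at 190000 nM, in the range 50000 nM to 700000 nM, which is expected to mean a step of a 1.0-fold higher number from compound 2 to compound 4 (0.01 log units; within the scatter).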

Compound 4, half-maximal inhibitory concentration: 10300 nM
Compound 4: middle estimate off by 18-fold (1.27 log units), on the high side; measured number below the stated range.
By their numbers in this assay, from the lowest: compound 4; then compound 1; then compounds 2 and 3 (each within the scatter of the next).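

In this assay the configuration at this saturated chain carbon counts on its own, and the compound drawn R gives the lower number of the pair (an 18-fold lower number from compound 2 to compound 4 (1.26 log units; beyond the scatter)). The earlier step at the same carbon (a 7.7-fold higher number from compound 1 to compound 2 (0.89 log units; beyond the scatter)) showed only that the substituent there matters, and it left the question of configuration untouched. The new step can be laid on the stereocentre alone, because nothing else separates the two compounds: the fact that compounds 2 and 4 differ only in the configuration as drawn

The compounds shown leave open whether configuration counts to the same extent when the rest of the molecule is that of compound 3, which carries no trifluoromethyl groups, or when an isopropyl group stands at this carbon as in compound 1. They also leave open whether a longer chain, a hydroxymethyl group or a carboxylic acid at this carbon, drawn in either configuration, would keep a number close to that of compound 4 (10300 nM).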